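The compounds below may be only part of what the source reports. "The series", "measured", "known", "first", "only" and "open" are said of these compounds alone.

Compound 1 (`CCCSc1nc(N/N=C/c2cccnc2)c2nnn(Cc3ccccc3)c2n1`) and compound 2 (`CCCSc1nc(N/N=C/c2cccs2)c2nnn(Cc3ccccc3)c2n1`) share one core and differ in a single group, and both were tested in a functional assay on MGC-803 cells (Homo sapiens) for antiproliferative activity, read by MTT assay, with a stated time of 72 h; on this read-out higher numbers stand for weaker inhibition and lower numbers for stronger inhibition. Compound 1 gives a measured number (38100 nM). Compound 2 gives only a limit of the assay and not a number (> 64000 nM). That limit is all that is known of its position (the limit of > 64000 nM in this assay, at which 1 of the 2 values shown sits).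

Compound 3 (`CCCSc1nc(N/N=C(\C)c2ccccc2)c2nnn(Cc3ccccc3)c2n1`) has not yet been measured. It differs from compound 2 by one exchange (a group of 9 heavy atoms (8 carbon, 1 nitrogen; one six-membered aromatic ring of carbon only) in place of a group of 7 heavy atoms (5 carbon, 1 nitrogen, 1 sulfur; one five-membered aromatic ring with 1 hetero atom), on a nitrogen on an aromatic ring): a group with a six-membered aromatic ring of carbon only replaces a group with a five-membered aromatic ring with 1 hetero atom, on a nitrogen on an aromatic ring.

Among the measured compounds shown here, only one measured step bears on this, the exchange of pyridin-3-yl for thiophen-2-yl (an at least 1.6-fold higher number from compound 1 to compound 2 (0.22 log units; that floor lies within the scatter)). Its floor lies within the scatter, so it fixes neither size nor direction. For the measured compounds named here, the best anchor is therefore the one real number, from compound 1 (38100 nM).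

The estimated step (an at least 1.8-fold lower number from compound 2 to compound 3 (0.26 log units; that floor lies within the scatter)) is expected to be small and, if anything, towards a lower number in this assay. Compound 3 is expected to give 35000 nM within an estimated range (8000 nM to 90000 nM).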

Compound 3, half-maximal inhibitory concentration: 25400 nM
Compound 3: middle estimate off by 1.4-fold (0.14 log units), on the high side; the measured number falls inside the stated range.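

In this assay, among the compounds shown here, replacing the group with a five-membered aromatic ring with 1 hetero atom by the group with a six-membered aromatic ring of carbon only gives an at least 2.5-fold lower number from compound 2 to compound 3 (0.40 log units; beyond the scatter), the first step in this set that clearly exceeds the usual variation, so this place on a nitrogen on an aromatic ring does respond to the group it carries. Going by these compounds, compound 2 gives only a limit of the assay and not a number, so that step is a minimum and its true size stays unknown: the limit of > 64000 nM in this assay, at which 1 of the 3 values shown sits. Compared with the pyridin-3-yl compound, the picture is different, with a 1.5-fold lower number from compound 1 to compound 3 (0.18 log units; within the scatter), so the groups of these two compounds cannot be told apart in this assay, and the clear difference holds only against the thiophen-2-yl compound.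

The compounds shown do not separate the effect of the ring in compound 3 from that of the methyl group it also carries on the carbon with a double bond to nitrogen. They also leave open how this place would respond to a ring bearing an amine or a carboxylic acid.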